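The source may hold more compounds than are shown below. What is called first, only, known or untested is meant among the compounds shown, and "the series" means these compounds.

In a functional assay on Flp-In T-REx293 cells for antagonist activity at Free fatty acid receptor 1 (Homo sapiens), read by calcium flux (on this read-out higher numbers stand for weaker inhibition and lower numbers for stronger inhibition), three compounds carry a value so far:

compound 1, `O=S1(=O)c2ccccc2CN1c1cc(F)cc(OCc2ccccc2)c1`, gives 2450 nM.
compound 2, `Cc1ccc(Oc2cc(F)cc(N3Cc4ccccc4S3(=O)=O)c2)cc1`, gives 2880 nM.
compound 3, `N#Cc1ccccc1Oc1cc(F)cc(N2Cc3ccccc3S2(=O)=O)c1`, gives > 100000 nM, which is a limit of this assay and not a number.

Compound 3 therefore stands apart from the other two: its entry is only a limit (the limit of > 100000 nM in this assay, at which 1 of the 3 values shown sits), and the steps leading to it are large, an at least 40-fold higher number from compound 1 to compound 3 (1.61 log units; beyond the scatter) and an at least 34-fold higher number from compound 2 to compound 3 (1.54 log units; beyond the scatter). Compound 1 and compound 2, by contrast, differ by a 1.2-fold higher number from compound 1 to compound 2 (0.07 log units; within the scatter), so the benzyl and the 4-methylphenyl groups on the oxygen behave alike here.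

Compound 4, `N#Cc1ccc(Oc2cc(F)cc(N3Cc4ccccc4S3(=O)=O)c2)cc1`, keeps the same atoms as compound 3 but joins them differently: 4-cyanophenyl in place of 2-cyanophenyl on an oxygen on an aromatic ring. For the measured compounds named here, no measured step swaps one cyanophenyl for another, so the bearing of the data is indirect. The two large steps show that the 2-cyanophenyl group costs much inhibition, while compound 2 shows that a phenyl bearing a 4-substituent is tolerated about as well as benzyl. On that basis compound 4 is expected to move back toward the numbers of compound 1 and compound 2, though how far is open, giving an expected step of an at least 6.6-fold lower number from compound 3 to compound 4 (0.82 log units; beyond the scatter). The estimate for compound 4 is 15000 nM, expected to fall between 2500 nM and 100000 nM.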

Compound 4, half-maximal inhibitory concentration: 617 nM
Beside the measured number, compound 4's estimate is 24-fold (1.39 log units) above it, and the stated range ends above it.
By their numbers in this assay, from the lowest: compound 4; then compounds 1 and 2 (each within the scatter of the next). At a limit, above all of these: compound 3.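

In this assay, where the nitrile sits on the phenyl ring on the oxygen decides the outcome, for the same atoms joined differently give an at least 160-fold lower number from compound 3 to compound 4 (2.20 log units; beyond the scatter). For the compounds shown here, the entry of compound 3 is only a limit of the assay: the limit of > 100000 nM in this assay, at which 1 of the 4 values shown sits. The 4-cyanophenyl group is not merely tolerated, and the earlier compounds did not show that a change at this place could strengthen inhibition beyond the level at which compound 1 and compound 2 lie within the scatter of each other, as the modest steps show: a 4.7-fold lower number from compound 2 to compound 4 (0.67 log units; beyond the scatter) and a 4.0-fold lower number from compound 1 to compound 4 (0.60 log units; beyond the scatter).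

As far as these compounds go, whether the gain belongs to the nitrile alone stays open, since a carboxylic acid, an amide or a chlorine atom in its place could match compound 4 or fall short of it. Whether a third placement of the nitrile on that phenyl ring would follow compound 3 or compound 4, and whether the gain would survive a change elsewhere in the shared core, also remains unanswered.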